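Butyl to difluorophenyl on the triazole of compound 2

A few compounds are considered here, and "the series" means these few. Any claim that something is new, unique, unknown or untested is made for them only; others in the source may bear on it.

The study compares three furanone triazoles in a functional assay on HepG2 cells (Homo sapiens) for antiproliferative activity, read by MTT assay, with a stated time of 72 h (a higher number here means a weaker inhibitor, a lower number a stronger inhibitor), and then looks ahead to a fourth. Compound 1 `O=C1O/C(=C\Cn2cc(-c3cc(F)cc(F)c3)nn2)C(OCc2ccccc2)=C1OCc1ccccc1` reaches only a limit of the assay, > 100000 nM. Compound 3 `CC(C)(C)OC(=O)N1CCN(C(=S)SCc2cn(C[C@H](O)[C@H]3OC(=O)C(OCc4ccccc4)=C3OCc3ccccc3)nn2)CC1` likewise stops at a limit, > 100000 nM. Within the data shown here, compound 2 `CCCCc1cn(C[C@H](O)[C@H]2OC(=O)C(OCc3ccccc3)=C2OCc2ccccc2)nn1` is the one member that yields a number, and in this assay compound 2 gives 32800 nM, so it stands as the only measured value among the three, the other two sitting at the limit of > 100000 nM in this assay, at which 2 of the 3 values shown sit.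

Compound 4 `O=C1O[C@H]([C@@H](O)Cn2cc(-c3cc(F)cc(F)c3)nn2)C(OCc2ccccc2)=C1OCc1ccccc1` is to be measured next. It differs from compound 2 in one place: 3,5-difluorophenyl in place of butyl on an aromatic carbon. Compound 1 carries the same 3,5-difluorophenyl on its triazole, yet on a different core, and its value is a limit; compound 4 keeps the core of compound 2. Among the measured compounds shown here, no measured pair separated by a single change exists here, so the expected size of the step rests only on the fact that compound 1 shows a limit while compound 2 shows a number. The step from compound 2 to compound 4 is expected to be a 2.0-fold higher number from compound 2 to compound 4 (0.30 log units; within the scatter), a move toward weaker inhibition beyond the scatter. Compound 4 is therefore estimated at 65000 nM, within a range from 20000 nM to 200000 nM, with a real chance that only a limit is reported.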

Compound 4, half-maximal inhibitory concentration: 11600 nM
Compound 4: middle estimate off by 5.6-fold (0.75 log units), on the high side; measured number below the stated range.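

In this assay, among these compounds, the change from butyl to 3,5-difluorophenyl gives a 2.8-fold lower number from compound 2 to compound 4 (0.45 log units; beyond the scatter), the first single change in this set that can be read. It shows that this aromatic carbon of the five-membered aromatic ring with 3 nitrogen accepts a six-membered aromatic ring in place of an open chain, with 8 heavy atoms entering where 4 leave, and that on the core shared by compound 2 and compound 4 the number moves modestly toward stronger inhibition rather than being lost. Compound 1 carries the same 3,5-difluorophenyl on a different core, and its > 100000 nM is a limit of the assay, so the effect of the group can be read only on the core of compound 4.

The compounds shown leave open whether the shift belongs to the aromatic ring itself or to its two fluorines, and whether a plain phenyl, a pyridine or a longer chain at this position would give a similar number. Any comparison with the compounds that stop at a limit cannot be read as a step: the limit of > 100000 nM in this assay, at which 2 of the 4 values shown sit.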